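This account rests on a few compounds, and the source may have more. Where it says the series, first, only, none or still open, it means among the compounds named here.

Measured compounds:
- compound 1, `O=C(CCCCCCc1ccccc1)c1nc(-c2cccs2)no1`, 1.6 nM
- compound 2, `O=C(CCCCCCc1ccccc1)c1noc(-c2ccco2)n1`, 8.5 nM
- compound 3, `O=C(CCCCCCc1ccccc1)c1ccc(-c2ccco2)nn1`, 40 nM

In an assay for inhibition of Fatty-acid amide hydrolase 1 (Rattus norvegicus), at pH 9.0 (on this read-out higher numbers stand for weaker inhibition and lower numbers for stronger inhibition), compound 3 gives the highest number of the three, so it is the weakest inhibitor here. Compound 2 sits nearest to it with a clearly lower number, and compound 1 is furthest away, with a much lower number still; both gaps are beyond the usual scatter.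

Compound 4, `COC(=O)c1cccc(-c2ccc(C(=O)CCCCCCc3ccccc3)nn2)n1`, has not been measured yet. It differs from compound 3 in one place: 6-(methoxycarbonyl)pyridin-2-yl in place of furan-2-yl on an aromatic carbon. Within the data shown here, no pair among the measured compounds shows this same exchange, so its effect can only be guessed. The larger group adds more hydrogen-bond acceptors than the furan-2-yl it replaces, but nothing measured here says which way that will pull the number.

Compound 4 is therefore expected to land close to compound 3, with a slight lean towards a lower number, giving an estimate of 25 nM within a range of 5 nM to 120 nM. The expected step from compound 3 to compound 4 is a 1.6-fold lower number from compound 3 to compound 4 (0.20 log units; within the scatter), well within what a single exchange of this size could plausibly produce.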

Compound 4, inhibition constant: 110 nM
Compound 4: middle estimate off by 4.4-fold (0.64 log units), on the low side; the measured number falls inside the stated range.
By their numbers in this assay, from the lowest: compound 1; then compound 2; then compound 3; then compound 4.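

In this assay, among these compounds, a 2.8-fold higher number from compound 3 to compound 4 (0.44 log units; beyond the scatter) gives the only single exchange that can be read so far, and it shows that this carbon, para to a large group, accepts 6-(methoxycarbonyl)pyridin-2-yl in place of furan-2-yl with only a modest loss, though one beyond the scatter. In this one pair, the entering group's extra heavy atoms and hydrogen-bond acceptors bring no stronger inhibition. Nothing measured here gives a reason for the loss.

The exchange alters the ring and adds the methoxycarbonyl at once, so the step cannot be divided between the two. As far as these compounds go, a plain pyridin-2-yl, or a carboxylic acid in place of the methoxycarbonyl, would be needed to show which part matters, and whether the same exchange acts alike on the cores of compound 1 and compound 2 remains open.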